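Lengthening the chain: compound 2 to compound 4

The source may hold more compounds than are shown below. What is called first, only, known or untested is meant among the compounds shown, and "the series" means these compounds.

In a functional assay on HEL cells (Homo sapiens) (a lower number here means that less compound is tolerated, a higher number that more compound is tolerated), compound 1 (`CCCCCCC#Cc1cc2cn(COCCO)c(=O)nc2o1`) gives > 50000 nM, which is a limit and not a number. Compound 2 (`CCCCCCCC#Cc1cc2cn(COCCO)c(=O)nc2o1`) gives > 50000 nM, also a limit. The series therefore shows (the limit of > 50000 nM in this assay, at which 2 of the 3 values shown sit), and compound 2 has no exact position on the scale. Going by the values given here, compound 3 (`CCCCCCCc1cc2cn(COCCO)c(=O)nc2o1`) gives 140000 nM, the only true number so far.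

Compound 4 (`CCCCCCCCC#Cc1cc2cn(COCCO)c(=O)nc2o1`) differs from compound 2 as follows: methyl in place of hydrogen on a saturated chain carbon, seven bonds along the chain from a triple-bonded carbon. This is methyl in place of hydrogen on a saturated chain carbon, seven bonds along the chain from a triple-bonded carbon.

The closest measured change is a step that the two limits leave unreadable from compound 1 to compound 2, so it gives no size or direction to carry forward. Among the compounds with values here, compound 3 at 140000 nM is the only guide to how high a measured value may lie. Compound 4 is therefore expected to remain poorly tolerated only at high concentrations, probably at or near the limit.

The expected change, a step that the limit leaves unreadable from compound 2 to compound 4, is an estimate set against a limit and not a readable step. For compound 4 the estimated value is 90000 nM, with an expected range of 35000 nM to 200000 nM.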

Compound 4, half-maximal cytotoxic concentration: 42000 nM
Estimate against measurement, compound 4: 2.1-fold (0.33 log units) above, within the range that was stated.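

Methyl in place of hydrogen on a saturated chain carbon, seven bonds along the chain from a triple-bonded carbon, gives the first step in this run of triple-bonded chains with a readable direction: an at least 1.1-fold lower number from compound 2 to compound 4 (0.07 log units; that floor lies within the scatter). The second readable step runs the same way: an at least 1.1-fold lower number from compound 1 to compound 4 (0.07 log units; that floor lies within the scatter). Both steps are floors set against a limit, and the step between compound 1 and compound 2 cannot be read: the limit of > 50000 nM in this assay, at which 2 of the 4 values shown sit.

Where compound 1 and compound 2 truly lie remains open, and with it the real size of both steps. Going by these compounds, how a longer chain, or a chain carrying an amine, would read in this assay also stays open.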